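The source may report more compounds than this note shows. Statements on the series, on what has been measured and on what is new or still open speak of the compounds shown alone.

Compound 1 `C=CCOc1ccc(Br)cc1C(=O)c1cccnc1` gives 88000 nM in a functional assay on IMR-32 cells (Homo sapiens) for cytotoxicity, read by sulforhodamine B assay, with a stated time of 48 h (on this read-out lower numbers stand for stronger inhibition and higher numbers for weaker inhibition), the highest of the three numbers recorded; the nearest to it is compound 2 `O=C(c1cccnc1)c1cccc(Cl)c1O` with 26000 nM, and the furthest is compound 3 `O=C(c1cccnc1)c1cc(Br)ccc1O` with 23400 nM. Compound 4 `C=CCOc1ccc(Cl)cc1C(=O)c1cccnc1` has not yet been measured in this assay. It differs from compound 1 in one place (chloro in place of bromo on an aromatic carbon).

Within the data shown here, no measured step bears directly on this change. Among the measured compounds shown here, the only step between measured compounds that differ in one place, a 3.8-fold lower number from compound 1 to compound 3 (0.58 log units; beyond the scatter), concerns the oxygen substituent and not the halogen. Compounds 2 and 3 carry chloro and bromo, but they also differ in where the halogen sits, so their two values say only that both lie close to one another and well under compound 1. With nothing that isolates the halogen swap, a step of no more than the usual scatter is expected from compound 1 to compound 4, with no firm direction, and the estimate leans slightly toward a higher number because compound 1 already stands at 88000 nM with the allyloxy group kept.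

Compound 4 is therefore estimated at 95000 nM, within a range from 45000 nM to 200000 nM, an expected step of a 1.1-fold higher number from compound 1 to compound 4 (0.03 log units; within the scatter).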

Compound 4, half-maximal inhibitory concentration: 91000 nM
Compound 4: middle estimate off by 1.0-fold (0.02 log units), on the high side; low and high end bracket the measured number.
By their numbers in this assay, from the lowest: compounds 3 and 2 (each within the scatter of the next); then compounds 1 and 4 (each within the scatter of the next).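

In this assay, exchanging the halogen gives a 1.0-fold higher number from compound 1 to compound 4 (0.01 log units; within the scatter), so on the ring position para to the allyloxy group, chloro and bromo cannot be told apart while the allyloxy group is kept. Among these compounds, the only earlier step between compounds differing in one place, a 3.8-fold lower number from compound 1 to compound 3 (0.58 log units; beyond the scatter), concerned the group on the oxygen, so this is the first reading that isolates the halogen, and it shows no effect of this change beyond the scatter. Nothing available explains why the two halogens read alike here.

As far as these compounds go, it remains open whether chloro and bromo would also read alike with hydrogen in place of allyl on the oxygen, where the number for the bromo compound 3 is 23400 nM. From the compounds shown here alone, it is also open whether this position tolerates groups of another kind, such as an amine, a carboxylic acid or a longer chain, as readily as it tolerates this exchange of one halogen for the other.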